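This account rests on a few compounds, and the source may have more. Where it says the series, first, only, none or still open, it means among the compounds named here.

Measured so far in a functional assay on OVCAR cells (Homo sapiens) for cytotoxicity, read by sulforhodamine B assay, with a stated time of 48 h; a higher number here means a weaker inhibitor, a lower number a stronger inhibitor:
compound 1 `COc1cc(C2CC(c3ccco3)=NN2C(C)=O)cc(OC)c1OC` gives 10900 nM
compound 2 `COc1ccc(C2CC(c3ccco3)=NN2C(C)=O)cc1OC` gives 31200 nM
compound 3 `COc1ccc(C2CC(c3cccc4ccccc34)=NN2C(C)=O)c(OC)c1OC` gives 1980 nM

Compound 3 has the lowest number of the three. The difference between the core of compound 3 and the core of compound 1 is not broken down here, so no single change accounts for it. Compound 1 and compound 2 differ in one place: hydrogen in place of methoxy on an aromatic carbon. That change gave a 2.9-fold higher number from compound 1 to compound 2 (0.46 log units; beyond the scatter), a step beyond the scatter but modest.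

Compound 4 `COc1ccc(C2CC(c3cccc4ccccc34)=NN2C(C)=O)cc1OC` is not yet measured in this assay. It differs from compound 3 by hydrogen in place of methoxy on an aromatic carbon. Among the compounds with values here, this is the same kind of change as the one from compound 1 to compound 2, but not the same: in compound 3 the carbon that loses the methoxy group is ortho to a large group, whereas in compound 1 it is meta to a large group; in both cases it is ortho to a methoxy group and meta to a methoxy group. The change occurs only twice among these compounds, so the earlier step is the only guide, and how the surroundings of the place affect it is not known from these data.

For compound 4 a step of a 3.0-fold higher number from compound 3 to compound 4 (0.48 log units; beyond the scatter) in this assay is expected. This rests on the earlier step, which for the same kind of change gave a 2.9-fold higher number from compound 1 to compound 2 (0.46 log units; beyond the scatter). Compound 4 is therefore estimated at 6000 nM, with a likely range from 2500 nM to 15000 nM.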

Compound 4, half-maximal inhibitory concentration: 2690 nM
Compound 4: the middle estimate sits 2.2-fold (0.35 log units) above what was measured, within the range that was stated.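

In this assay, hydrogen in place of methoxy on the core of compound 3 gave a 1.4-fold higher number from compound 3 to compound 4 (0.13 log units; within the scatter), so this pair cannot be told apart in this assay. Although only the earlier step lies beyond the scatter, the two steps do not differ by more than two such steps can differ through scatter alone: the same change on two cores in this assay, a 2.9-fold higher number (0.46 log units; beyond the scatter) from compound 1 to compound 2 and a 1.4-fold higher number (0.13 log units; within the scatter) from compound 3 to compound 4, 2.1-fold (0.32 log units) apart, within the scatter of two such steps. This means the data do not show that the change behaves differently on the two cores, but with only two pairs they do not establish that it carries over at a fixed size either, and any effect of the carbon being ortho to a large group in compound 3 can be neither shown nor excluded.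

Still open is how a hydroxyl group, an amine or a longer alkoxy chain would read in this assay at the place of this methoxy group, since the only replacement shown there is hydrogen. Also open, as far as these compounds go, is whether the step from methoxy to hydrogen would stay within the scatter or move beyond it on a third core, for example one carrying a carboxylic acid.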